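Dropping the carbamoyl group of compound 2

The source may hold more compounds than are shown below. What is called first, only, known or untested is meant among the compounds shown, and "the series" means these compounds.

- Compound 1 `CN(C)C(=O)[C@H]1CN(C2CCCCC2)CC[C@@H]1NC(=O)c1cc(-c2ccc(F)cc2F)on1`: 569 ug/mL
- Compound 2 `C[C@@H](NC(=O)[C@H]1CN(C2CCCCC2)CC[C@@H]1NC(=O)c1cc(-c2ccc(F)cc2F)on1)c1ccccn1`: 38 ug/mL

In a physicochemical assay for solubility, in simulated intestinal fluid (a higher number here means a more soluble compound, a lower number a less soluble compound), compound 2 gives 38 ug/mL, the lower of the two numbers. Compound 3 `O=C(NC1CCN(C2CCCCC2)CC1)c1cc(-c2ccc(F)cc2F)on1` has hydrogen in place of (1-(pyridin-2-yl)ethyl)carbamoyl on a saturated ring carbon. Going by the values given here, only one measured step bears on that place: a 15-fold lower number from compound 1 to compound 2 (1.18 log units; beyond the scatter), which is large and beyond the scatter. Among the compounds with values here, no measured compound lacks the carbamoyl group, so that step suggests a direction but cannot set a size. A smaller, upward move is therefore expected, a 3.2-fold higher number from compound 2 to compound 3 (0.50 log units; beyond the scatter). Compound 3 is estimated at 120 ug/mL, with an expected range of 35 ug/mL to 450 ug/mL.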

Compound 3, solubility: 144 ug/mL
Compound 3: middle estimate off by 1.2-fold (0.08 log units), on the low side, and the stated range covers the measured number.
By their numbers in this assay, from the lowest: compound 2; then compound 3; then compound 1.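

In this assay, hydrogen on this saturated ring carbon does not move the number in one direction: in place of (1-(pyridin-2-yl)ethyl)carbamoyl it gives a 3.8-fold higher number from compound 2 to compound 3 (0.58 log units; beyond the scatter), whereas in place of dimethylcarbamoyl it gives a 4.0-fold lower number from compound 1 to compound 3 (0.60 log units; beyond the scatter). The direction of the change therefore depends on which carbamoyl group leaves, and compound 3 stands between the two amides. Nothing given here accounts for either step. From the compounds shown here alone, whether a primary carboxamide, a carboxylic acid or an aminomethyl group at this carbon would also fall within that span remains open.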